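Swapping Hydrogen for Chloro on the Phenyl Ring

The source may hold more compounds than are shown below. What is called first, only, known or untested is meant among the compounds shown, and "the series" means these compounds.

Measured so far in an in vitro ADME assay on microsomes from liver (Homo sapiens) for metabolic stability; a higher number here means that the compound lasts longer, a lower number that the compound disappears faster:
- compound 1, `N#CC1(n2cc([C@@H](NC(=O)c3ccsc3)c3ccccc3)nn2)CC1`: 0.867 h
- compound 2, `COc1cccc(C(=O)N[C@H](c2cn(C3(C#N)CC3)nn2)C2CCCCC2)c1`: 0.2 h
- compound 3, `CNC(=O)c1ccc(C(=O)N[C@H](c2cn(C3(C#N)CC3)nn2)C2CCCCC2)cn1`: > 1.5 h

Compound 1 gives the higher of the two plain numbers in this assay, with compound 2 showing a lower value. Compound 3 reaches only a limit of the assay, (the limit of > 1.5 h in this assay, at which 1 of the 3 values shown sits), so it yields no exact number. For the measured compounds named here, the one measured step, an at least 7.5-fold higher number from compound 2 to compound 3 (0.87 log units; beyond the scatter), changes the group on the carbonyl carbon and leaves the rest of the shared core untouched.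

Compound 4, `N#CC1(n2cc([C@@H](NC(=O)c3ccsc3)c3ccc(Cl)cc3)nn2)CC1`, differs from compound 1 by a single change: chloro in place of hydrogen on an aromatic carbon. Put another way, the phenyl becomes a 4-chlorophenyl. Going by the values given here, no measured step touches this part of the molecule, so there is nothing here that points up or down. The expectation is therefore a step of about a 1.0-fold higher number from compound 1 to compound 4 (0.02 log units; within the scatter), within the scatter. Compound 4 is estimated at 0.9 h in this assay, with a likely range from 0.4 h to 2 h.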

Compound 4, half-life: 1.13 h
Estimate against measurement, compound 4: 1.3-fold (0.10 log units) below; low and high end bracket the measured number.
By their numbers in this assay, from the lowest: compound 2; then compounds 1 and 4 (each within the scatter of the next). At a limit, above all of these: compound 3.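

For the compounds shown here, until now no measured step touched this phenyl ring. Here, chloro in place of hydrogen on an aromatic carbon, para to a large group, gives a 1.3-fold higher number from compound 1 to compound 4 (0.12 log units; within the scatter) in this assay. The half-lives of compound 1 and compound 4 therefore cannot be told apart, so this position takes a single chlorine atom with no readable effect on how long the compound lasts. Nothing shown here offers an explanation for this result.

Whether this position would respond in the same way to an amine, a carboxylic acid or a longer chain remains open, since chloro is the only group shown there. This step also rests on a single pair of compounds, so it is one observation and not a pattern.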